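Ester chain extension on the shared core

The compounds below may be only part of what the source reports. "The series", "measured", "known", "first", "only" and "open" are said of these compounds alone.

Compound 1 `COC(=O)/C=C/c1cccc(N(Cc2ccc(/C=C/c3cccc(F)c3)cc2)C(=O)C2CCCCC2)c1` gives 86 nM in an assay on isolated protein with Bile acid receptor (Homo sapiens) as the target; a lower number here means that less compound is needed, a higher number that more compound is needed for the effect. Compound 2 `COC(=O)/C=C/c1ccc(CN(C(=O)C2CCCCC2)c2cccc(/C=C/C(=O)OC)c2)cc1` carries a methoxycarbonyl in place of the 3-fluorophenyl on a double-bonded chain carbon, and the step of an at least 11-fold higher number from compound 1 to compound 2 (1.06 log units; beyond the scatter) is large. In this assay, going by these compounds, compound 2 reaches only the limit of the measurement, > 1000 nM, so its exact position is unknown (the limit of > 1000 nM in this assay, at which 1 of the 2 values shown sits). Compound 3 `CCOC(=O)/C=C/c1ccc(CN(C(=O)C2CCCCC2)c2cccc(/C=C/C(=O)OC)c2)cc1` differs from compound 2 by methyl in place of hydrogen on a saturated chain carbon bound to an oxygen next to a carbonyl group. Among the compounds with values here, no measured step covers this change; the single measured step concerns another position and gives no guide to its size. For the step that the limit leaves unreadable from compound 2 to compound 3 no change beyond the scatter is expected. Compound 3 is therefore estimated at 2000 nM, between 700 nM and 6000 nM, most probably again reported only as a limit.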

Compound 3, half-maximal effective concentration: > 1000 nM
Compound 3 was reported as a limit; the forecaster's own chance of this, stated with the estimate: 80%; the middle value is on the limit's open side.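

In this assay compound 3 gives > 1000 nM, which is a limit of the assay. Ethoxycarbonyl in place of 3-fluorophenyl gives an at least 11-fold higher number from compound 1 to compound 3 (1.06 log units; beyond the scatter), so the added methyl on the saturated chain carbon bound to an oxygen does not bring this ester end into the measurable range, and methoxycarbonyl is no longer the only ester group seen with a large step from compound 1. The step between the two esters themselves cannot be read: the limit of > 1000 nM in this assay, at which 2 of the 3 values shown sit.

Going by these compounds, it remains open how far past the limit compound 2 and compound 3 lie, and whether the added methyl changes anything at all. Also open, on these data alone, is whether a carboxylic acid, an amine or a longer chain at this end of the double-bonded chain would return a measurable value.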